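The source may report more compounds than this note shows. Statements on the series, on what has been measured and on what is new or still open speak of the compounds shown alone.

Compound 2 `O=C(Nc1ccccc1)c1cn(-c2ccccc2)nc1-c1ccc([N+](=O)[O-])cc1` gives 2260 nM in a functional assay on MCF7 cells (Homo sapiens) for cytotoxicity, read by MTT assay, with a stated time of 48 h (a higher number here means a weaker inhibitor, a lower number a stronger inhibitor), the higher of the two numbers recorded there, while compound 1 `CCOc1ccc(NC(=O)c2cn(-c3ccccc3)nc2-c2ccc(Cl)cc2)cc1` gives 560 nM in this assay. The two compounds differ in more than one place, so no single change can be read from the gap between them. Compound 3 `CCOc1ccc(NC(=O)c2cn(-c3ccccc3)nc2-c2ccc([N+](=O)[O-])cc2)cc1` is the compound still to be measured. It differs from compound 2 by ethoxy in place of hydrogen on an aromatic carbon. No step of this kind has been measured among these compounds, so its size and direction in this assay are open. The ethoxy group is also carried by compound 1, whose value in this assay, 560 nM, is the lower of the two, though compound 1 differs elsewhere as well. Compound 3 is therefore expected to give a somewhat lower number, estimated at 1300 nM with a range from 500 nM to 3500 nM, a step of a 1.7-fold lower number from compound 2 to compound 3 (0.24 log units; within the scatter) expected to be small and possibly within the scatter.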

Compound 3, half-maximal inhibitory concentration: 460 nM
Beside the measured number, compound 3's estimate is 2.8-fold (0.45 log units) above it; measured number below the stated range.
By their numbers in this assay, from the lowest: compounds 3 and 1 (each within the scatter of the next); then compound 2.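

In this assay, among these compounds, the change from anilino to (4-ethoxyphenyl)amino, with ethoxy para to a large group, gives a 4.9-fold lower number from compound 2 to compound 3 (0.69 log units; beyond the scatter), which is the first single-place reading at this position and lies beyond the scatter. With the ethoxy group held in place, nitro in place of chloro on the other aromatic ring gives a 1.2-fold lower number from compound 1 to compound 3 (0.09 log units; within the scatter), within the scatter, so this assay does not separate these two groups in the ethoxy compounds. Nothing shown here accounts for the size of the ethoxy step.

Going by these compounds, the ethoxy step is read only with nitro on the other ring, so whether it carries over to the chloro compounds remains open. Also open, on these data alone, is how a methoxy group, a longer alkoxy chain or an amine would compare with ethoxy at this position.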